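Aryl swap on the shared core: outlook for compound 4

A few compounds are considered here, and "the series" means these few. Any claim that something is new, unique, unknown or untested is made for them only; others in the source may bear on it.

Measured so far in a functional assay on B16-F0 cells (Mus musculus) for inhibition, read by CCK-8 assay, with a stated time of 48 h; on this read-out higher numbers stand for weaker inhibition and lower numbers for stronger inhibition:
compound 1 `COc1cc(-c2ccnc3cc(-c4ccc(C)cc4)nn23)cc(OC)c1OC` gives 21 nM
compound 2 `COc1cc(-c2ccnc3cc(-c4ccc5cc[nH]c5c4)nn23)cc(OC)c1OC` gives 55 nM
compound 3 `COc1cc(-c2ccnc3cc(-c4ccc(C(C)(C)C)cc4)nn23)cc(OC)c1OC` gives only > 10000 nM, a limit of the assay

Compound 3 therefore has no number in this assay, only the limit at which it sits (the limit of > 10000 nM in this assay, at which 1 of the 3 values shown sits). Compounds 1 and 2 both give numbers, separated by a 2.6-fold higher number from compound 1 to compound 2 (0.42 log units; beyond the scatter). The two steps into compound 3 are the large ones: an at least 470-fold higher number from compound 1 to compound 3 (2.67 log units; beyond the scatter) and an at least 180-fold higher number from compound 2 to compound 3 (2.25 log units; beyond the scatter).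

The step to compound 4 `COc1ccc(-c2cc3nccc(-c4cc(OC)c(OC)c(OC)c4)n3n2)cc1F` changes the same aromatic carbon: 3-fluoro-4-methoxyphenyl in place of 4-(tert-butyl)phenyl on an aromatic carbon. Of the measured steps, an at least 470-fold higher number from compound 1 to compound 3 (2.67 log units; beyond the scatter) bears most directly, since it shows what the tert-butyl brought relative to methyl on that phenyl; an at least 180-fold higher number from compound 2 to compound 3 (2.25 log units; beyond the scatter) points the same way from a different starting aryl. Compound 4 carries neither tert-butyl nor methyl nor indolyl, so the precise landing point cannot be read from the three compounds, but undoing the tert-butyl is expected to recover a large part of what was lost, and a large step downward is expected, an at least 250-fold lower number from compound 3 to compound 4 (2.39 log units; beyond the scatter).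

Compound 4 is estimated at 40 nM in this assay, within 10 nM to 250 nM.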

Compound 4, half-maximal inhibitory concentration: 3950 nM
Beside the measured number, compound 4's estimate is 99-fold (1.99 log units) below it; the whole stated range lies below it.
By their numbers in this assay, from the lowest: compound 1; then compound 2; then compound 4. At a limit, above all of these: compound 3.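

In this assay, 3-fluoro-4-methoxyphenyl on this aromatic carbon of the five-membered aromatic ring gives only a partial return from the tert-butyl compound, an at least 2.5-fold lower number from compound 3 to compound 4 (0.40 log units; beyond the scatter), while it remains far from the other two aryl groups, with a 72-fold higher number from compound 2 to compound 4 (1.86 log units; beyond the scatter) and a 190-fold higher number from compound 1 to compound 4 (2.27 log units; beyond the scatter). The earlier compounds shown here could be read as a penalty specific to the 4-(tert-butyl)phenyl group, but compound 4 shows that an aryl without tert-butyl can also lose most of the activity seen with 4-methylphenyl and 1H-indol-6-yl, so this position is more selective among aryl groups than those compounds showed. The full size of the return to compound 4 cannot be fixed, as compound 3 has only a limit of the assay: the limit of > 10000 nM in this assay, at which 1 of the 4 values shown sits.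

Which part of the new aryl group goes with the loss stays open, as the fluorine and the methoxy enter together in compound 4, and a phenyl carrying only one of them would separate the two. Also open, from the compounds shown here alone, is how this position would respond to an aryl group bearing an amine or a carboxylic acid.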